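The source may report more compounds than this note shows. Statements on the series, on what has been measured and on what is new or still open speak of the compounds shown alone.

This account concerns a small set of compounds built on one shared core and tested in a functional assay on RCC4 cells (Homo sapiens) for inhibition, read by XTT assay, with a stated time of 4 days; on this read-out lower numbers stand for stronger inhibition and higher numbers for weaker inhibition. Compound 1 `Cc1cccc(Nc2nc(-c3ccncc3)c(C)s2)c1` gives 10000 nM in this assay. Compound 2 `Cc1ccc(Nc2nc(-c3ccncc3)cs2)cc1O` gives 12000 nM in this assay, and compound 3 `Oc1ccc(Nc2nc(-c3ccncc3)cs2)cc1` gives 5370 nM in this assay. Among these three numbers compound 1 stands second highest; its gap to compound 2 and its gap to compound 3 both fall within the usual scatter of repeated measurements, so the three cannot be ranked against one another on this evidence.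

The compound now in question is compound 4 `COC(=O)C=CC(=O)c1sc(Nc2cccc(C)c2)nc1-c1ccncc1`. Relative to compound 1 it carries (2-(methoxycarbonyl)ethenyl)carbonyl in place of methyl on an aromatic carbon. Going by the values given here, no pair among the measured compounds shows a change of this kind, so nothing measured here tells how such a replacement shifts the read-out. The expectation therefore rests on compound 1 alone, and compound 4 is expected to remain close to it, with the step from compound 1 to compound 4 estimated as a 1.4-fold lower number from compound 1 to compound 4 (0.15 log units; within the scatter), a change not clearly beyond the scatter in either direction. On that basis compound 4 is estimated at 7000 nM in this assay, within a range from 1500 nM to 30000 nM.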

Compound 4, half-maximal inhibitory concentration: 2510 nM
Compound 4: middle estimate off by 2.8-fold (0.45 log units), on the high side; measured number inside the range.
By their numbers in this assay, from the lowest: compound 4; then compounds 3, 1 and 2 (each within the scatter of the next, the first and the last beyond it).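

In this assay, going by these compounds alone, putting (2-(methoxycarbonyl)ethenyl)carbonyl in place of methyl on the aromatic carbon next to the ring sulfur brings a 4.0-fold lower number from compound 1 to compound 4 (0.60 log units; beyond the scatter), the only step in this set and one that lies beyond the scatter. Within the data shown here, this position, next to the ring atom that bears a pyridin-4-yl group, therefore accepts a group of 8 heavy atoms with 3 hydrogen-bond acceptors, where methyl has none, without any loss of inhibition; the earlier compounds, whose numbers could not be ranked against one another, gave no step at this position at all. Nothing in the available data accounts for the lower number.

On these data alone, the step rests on a single pair, so it stays open which part of the entering group goes with it: a carboxylic acid in place of the methyl ester, an amide, or a saturated chain in place of the ethenyl link would help to separate the parts. As far as these compounds go, it is also open whether the same group would give a similar step on a compound with a hydroxyl on the other aromatic ring, as compound 3 carries.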